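Swapping a Nitro Group for Isopropyl on a Shared Core

This account rests on a few compounds, and the source may have more. Where it says the series, first, only, none or still open, it means among the compounds named here.

Compound 1 `Cc1cnc(Nc2ccc([N+](=O)[O-])cc2)nc1Nc1nc2ccccc2s1` has the highest number of the three compounds measured in a functional assay on HeLa cells (Homo sapiens) for antiproliferative activity, read by MTT assay, with a stated time of 48 h (on this read-out lower numbers stand for stronger inhibition and higher numbers for weaker inhibition), where compound 1 gives 34300 nM. Compound 3 `Cc1ccc2nc(Nc3nc(Nc4ccc(S(C)(=O)=O)cc4)ncc3F)sc2c1` gives 17200 nM in this assay, a number within the usual scatter of that of compound 1, so the two cannot be told apart. Compound 2 `COc1ccc2nc(Nc3ccnc(Nc4ccc(S(C)(=O)=O)cc4)n3)sc2c1` gives 4130 nM in this assay, a gap from compound 1 that lies beyond the scatter. Compound 4 `Cc1cnc(Nc2ccc(C(C)C)cc2)nc1Nc1nc2ccccc2s1` has not yet been measured. It differs from compound 1 in one place: isopropyl in place of nitro on an aromatic carbon. Going by the values given here, no pair of measured compounds shares this change, so no measured step shows what it does to the numbers. With nothing to lean on, the step from compound 1 to compound 4 is expected to be small, a 1.4-fold lower number from compound 1 to compound 4 (0.14 log units; within the scatter), with no direction beyond the scatter. On that basis compound 4 is expected to give about 25000 nM in this assay, estimated within a range from 8000 nM to 80000 nM.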

Compound 4, half-maximal inhibitory concentration: > 50000 nM
Compound 4 gave a limit, no number; the forecaster's own chance of this, stated with the estimate: 15%; middle value at least 2.0-fold (0.30 log units) away from the limit.
By their numbers in this assay, from the lowest: compound 2; then compounds 3 and 1 (each within the scatter of the next). At a limit, above all of these: compound 4.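

In this assay, compound 4 stands at a limit of the assay and not at a number: the limit of > 50000 nM in this assay, at which 1 of the 4 values shown sits. The change therefore reads as an at least 1.4-fold higher number from compound 1 to compound 4 (0.16 log units; that floor lies within the scatter), which gives only a floor for the step, and that floor does not separate the two compounds. Going by these compounds alone, still, this is the first view of this place on the shared core with another group: isopropyl, built of carbon only and with no hydrogen-bond acceptors, replaces nitro, and the read-out shows no gain in inhibition over compound 1.

Going by these compounds, how far compound 4 truly lies from compound 1 remains open. So does whether any group on this aromatic carbon can lower the number, for instance an amine or a carboxylic acid in place of nitro.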